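Allyl Thioether Replaces Bromobenzyl in a Cell Inhibition Series

The source may report more compounds than this note shows. Statements on the series, on what has been measured and on what is new or still open speak of the compounds shown alone.

The series rests on a shared core carrying a methyl group, an anilino-type pyrazole substituent and a thioether arm. For the measured compounds named here, compound 1 `Cc1cc(Nc2ccn(Cc3cccc4ccccc34)n2)n2nc(SCc3ccc(Br)cc3)nc2n1` is the only member with a numerical result: in an ADME assay on GES1 cells (Homo sapiens) for inhibition, read by MTT assay, with a stated time of 72 h (a higher number here means a weaker inhibitor, a lower number a stronger inhibitor), compound 1 gives 30000 nM. Compound 2 `Cc1cc(Nc2cc(-c3ccccc3)[nH]n2)n2nc(SCc3cccc(Br)c3)nc2n1` is reported in this assay only as a limit, > 50000 nM, and so its true value is not known; it sits at the limit of > 50000 nM in this assay, at which 1 of the 2 values shown sits. Compound 3 `C=CCSc1nc2nc(C)cc(Nc3cc(-c4ccccc4)[nH]n3)n2n1` has not yet been measured. It differs from compound 2 by vinyl in place of 3-bromophenyl on a saturated chain carbon bound to a sulfur, so the thioether arm shrinks from (3-bromobenzyl)sulfanyl to allylsulfanyl while the rest of the molecule is unchanged. With compound 2 already at the limit, the step of an at least 1.1-fold lower number from compound 2 to compound 3 (0.04 log units; that floor lies within the scatter) is expected to be small and without clear direction. Compound 3 is expected to give about 45000 nM, within 15000 nM to 100000 nM, and a limit rather than a number would not be surprising.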

Compound 3, half-maximal inhibitory concentration: > 50000 nM
Compound 3: no number, only a limit; the forecaster's own chance of this, stated with the estimate: 60%; at least 1.1-fold (0.04 log units) between middle value and limit.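

In this assay compound 3 gives > 50000 nM as a limit of the assay, not a number. For the compounds shown here, compound 2 also stands at a limit, so no step between compound 2 and compound 3 can be read. Going by these compounds, whether allylsulfanyl or (3-bromobenzyl)sulfanyl gives the stronger inhibitor remains open.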